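Series notes: amide nitrogen substituent, hydroxypropyl to allyl

The source may report more compounds than this note shows. Statements on the series, on what has been measured and on what is new or still open speak of the compounds shown alone.

The three measured compounds share one core and differ only in the group on the amide-type nitrogen. Compound 1 `Cc1ccc(OCC(=O)N(Cc2cccs2)C2COC2)cc1` gives 23000 nM in an assay on HEK293 cells for agonist activity at transient receptor potential cation channel subfamily M member 8 (Homo sapiens), read by fluorescence and calcium flux, with a stated time of 15 min; a lower number here means that less compound is needed, a higher number that more compound is needed for the effect. Compound 2 `Cc1ccc(OCC(=O)N(Cc2cccs2)c2c[nH]nc2C)cc1` gives 0.4 nM in this assay, and compound 3 `Cc1ccc(OCC(=O)N(CCCO)Cc2cccs2)cc1` gives 3000 nM. Compound 3 therefore stands second highest of the three numbers: its nearest neighbour is compound 1, with a 7.7-fold lower number from compound 1 to compound 3 (0.88 log units; beyond the scatter), and its furthest is compound 2, with a 7500-fold higher number from compound 2 to compound 3 (3.88 log units; beyond the scatter).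

Compound 4 `C=CCN(Cc1cccs1)C(=O)COc1ccc(C)cc1` is not yet measured. It differs from compound 3 by vinyl in place of 2-hydroxyethyl on a saturated chain carbon bound to an amide-type nitrogen. Going by the values given here, no measured step repeats this exchange. The two steps that touch compound 3 both replace the whole group on the amide-type nitrogen with a ring, and neither shows what removal of the hydroxyl from a short chain does. Among the compounds with values here, the step of a 7.7-fold lower number from compound 1 to compound 3 (0.88 log units; beyond the scatter) is the only one between two non-aromatic groups and is modest in size; the step of a 58000-fold lower number from compound 1 to compound 2 (4.76 log units; beyond the scatter) is large but involves 3-methyl-1H-pyrazol-4-yl, which is not at issue here.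

With so little to go on, a modest step in this assay is expected, most likely toward a higher number, as a 2.0-fold higher number from compound 3 to compound 4 (0.30 log units; within the scatter). Compound 4 is estimated at 6000 nM, with a range from 1500 nM to 30000 nM.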

Compound 4, half-maximal effective concentration: 20 nM
Compound 4: the middle estimate sits 300-fold (2.48 log units) above what was measured, and the stated range ends above it.
By their numbers in this assay, from the lowest: compound 2; then compound 4; then compound 3; then compound 1.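

Going by these compounds alone, at the amide-type nitrogen, an open chain can move the number in this assay by a large amount: the exchange of 3-hydroxypropyl for allyl gives a 150-fold lower number from compound 3 to compound 4 (2.18 log units; beyond the scatter), whereas the only earlier step between non-aromatic groups was modest. Allyl also stands far from oxetan-3-yl, with a 1200-fold lower number from compound 1 to compound 4 (3.06 log units; beyond the scatter), so a large drop at this position does not depend on 3-methyl-1H-pyrazol-4-yl, although that group still gives the lowest number of the series, with a 50-fold higher number from compound 2 to compound 4 (1.70 log units; beyond the scatter). No measurement to hand explains why this exchange has so large an effect.

The single step from compound 3 to compound 4 removes the hydroxyl and introduces the double bond together, so the compounds shown do not separate the two changes. From the compounds shown here alone, how a plain propyl group, a 3-aminopropyl chain or a longer alkenyl chain on the same nitrogen would read in this assay remains open, as does whether any open chain can approach the number given by 3-methyl-1H-pyrazol-4-yl.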